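Pyridin-3-yl to pyrimidin-5-yl on the aminopyridine arm

This account rests on a few compounds, and the source may have more. Where it says the series, first, only, none or still open, it means among the compounds named here.

Measured compounds:
compound 1 `Cc1ccc(C(=O)Nc2cc(-c3cnn(C)c3)cc(C(F)(F)F)c2)cc1Nc1cc(-c2cccnc2)ccn1`, > 80000 nM
compound 2 `Cc1cn(-c2cc(NC(=O)c3ccc(C)c(Nc4cc(-c5cccnc5)ccn4)c3)cc(C(F)(F)F)c2)cn1`, > 80000 nM
compound 3 `Cc1ccc(C(=O)Nc2ccc(CN3CCN(C)CC3)c(C(F)(F)F)c2)cc1Nc1cc(-c2cccnc2)ccn1`, 14000 nM

In a toxicity assay on HEK293 cells (Homo sapiens) for cytotoxicity, read by MTT assay, with a stated time of 48 h (a lower number here means a stronger inhibitor, a higher number a weaker inhibitor), compound 1 gives > 80000 nM, which is a limit of the assay and not a number. Compound 2 likewise gives > 80000 nM, again a limit. Among the measured compounds shown here, compound 3 gives 14000 nM in this assay, the only plain number in the set. For the measured compounds named here, the one single-point step, a step that the two limits leave unreadable from compound 1 to compound 2, cannot be read because both ends sit on the limit (the limit of > 80000 nM in this assay, at which 2 of the 3 values shown sit); compound 3 differs from compound 1 in more than one place, so its value shows only that a number can be reached.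

Compound 4 `Cc1ccc(C(=O)Nc2cc(-c3cnn(C)c3)cc(C(F)(F)F)c2)cc1Nc1cc(-c2cncnc2)ccn1` carries the change (pyrimidin-5-yl in place of pyridin-3-yl on an aromatic carbon), on the six-membered aromatic ring with one nitrogen, opposite the ring nitrogen; cut one bond further out it reads 4-(pyridin-3-yl)pyridin-2-yl to 4-(pyrimidin-5-yl)pyridin-2-yl. Going by the values given here, no measured step bears on this change. Compound 4 is therefore expected to stay at the limit, with an estimate of 80000 nM. For compound 4 the expected range runs from 30000 nM to 200000 nM. The step this expectation means is a number no higher from compound 1 to compound 4 (the limit leaves the size open).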

Compound 4, half-maximal inhibitory concentration: > 80000 nM
Compound 4: no number, only a limit; the forecaster's own chance of this, stated with the estimate: 75%; the middle value sits exactly at the limit.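

In this assay compound 4 gives > 80000 nM, a limit and not a number. No step from compound 1 to compound 4 can be read, because both ends sit on a limit: the limit of > 80000 nM in this assay, at which 3 of the 4 values shown sit.

Left open is whether pyrimidin-5-yl in place of pyridin-3-yl shifts the value at all, and how far compound 1, compound 2 and compound 4 actually lie from one another.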